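Swapping a Terminal Hydroxyl for Piperidine on a Benzamide Chain

The compounds below may be only part of what the source reports. "The series", "measured", "known", "first", "only" and "open" are said of these compounds alone.

Compound 1 `COc1cc(N)c(Cl)cc1C(=O)NC1CCNCC1` carries a bare ring amine; in a functional assay on HEK293 cells for agonist activity at 5-hydroxytryptamine receptor 4 (Homo sapiens), read by cAMP accumulation (a lower number here means that less compound is needed, a higher number that more compound is needed for the effect), compound 1 gives 398 nM. Within the data shown here, compound 2 `COc1cc(N)c(Cl)cc1C(=O)NC1CCN(CCCCCCCCO)CC1` adds an 8-hydroxyoctyl chain on that nitrogen, and in this assay compound 2 gives 15.9 nM, the lowest of the two numbers measured, separated from its only neighbour by the step of a 25-fold lower number from compound 1 to compound 2 (1.40 log units; beyond the scatter). Compound 3 `COc1cc(N)c(Cl)cc1C(=O)NC1CCN(CCCCCN2CCCCC2)CC1` alters the far end of that chain: piperidin-1-yl in place of 3-hydroxypropyl on a saturated chain carbon, five bonds along the chain from an amine nitrogen in a ring. Among the measured compounds shown here, the one measured step concerns adding the chain itself, not changing its end, so no directly comparable step exists; the expectation is a step of a 1.6-fold lower number from compound 2 to compound 3 (0.20 log units; within the scatter), within the scatter. Compound 3 is therefore estimated at 10 nM, ranging from 2 nM to 60 nM.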

Compound 3, half-maximal effective concentration: 5.01 nM
For compound 3 the middle estimate is 2.0-fold (0.30 log units) above the measured one; the range from low to high includes it.
By their numbers in this assay, from the lowest: compound 3; then compound 2; then compound 1.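

The earlier step showed only that adding a chain on the ring nitrogen lowers the number; this one shows that the far end of that chain matters too. In this assay, piperidin-1-yl in place of 3-hydroxypropyl gives a 3.2-fold lower number from compound 2 to compound 3 (0.50 log units; beyond the scatter) and so the terminal hydroxyl is not required for a low number at this position. Nothing available explains why the number falls. Still open, going by these compounds, is whether another amine at the chain end, such as morpholine or dimethylamine, would act like piperidine, and how a shorter or longer chain carrying it would compare.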